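Benzylamide to chloroanilide: an expected small gain

A few compounds are considered here, and "the series" means these few. Any claim that something is new, unique, unknown or untested is made for them only; others in the source may bear on it.

The series shares one core and differs in the substituent on the aromatic ring. In an assay on HEK293 cells for inhibition of protein deacetylase HDAC6 (Homo sapiens) (on this read-out higher numbers stand for weaker inhibition and lower numbers for stronger inhibition), compound 1 `CCSC(=S)SCC(=O)c1cccc(S(=O)(=O)N(C)c2ccc(OC)cc2)c1` gives 2040 nM and compound 3 `CCSC(=S)SCC(=O)c1ccc(S(=O)(=O)Nc2ccc(OC)cc2)cc1` gives 245 nM. Compound 2 `CCSC(=S)SCC(=O)c1ccc(C(=O)NCc2ccccc2)cc1` stands between them, with the second highest number of the three; in this assay compound 2 gives 830 nM, a step beyond the scatter away from each of the other two. Compound 4 `CCSC(=S)SCC(=O)c1ccc(C(=O)Nc2ccc(Cl)cc2)cc1` has not yet been measured; it differs from compound 2 by 4-chlorophenyl in place of benzyl on an amide-type nitrogen. Going by the values given here, no measured pair shows this change, so the expectation rests on the spread of the three numbers alone. A small step toward a lower number, barely beyond the scatter, is expected from compound 2 to compound 4 (a 1.7-fold lower number from compound 2 to compound 4 (0.22 log units; within the scatter)). Compound 4 is therefore estimated at 500 nM, with a range from 150 nM to 1600 nM.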

Compound 4, half-maximal inhibitory concentration: 1450 nM
The estimate for compound 4 lay 2.9-fold (0.46 log units) below the measured number; measured number inside the range.
By their numbers in this assay, from the lowest: compound 3; then compounds 2, 4 and 1 (each within the scatter of the next, the first and the last beyond it).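

In this assay, going by these compounds alone, this pair gives the first direct reading of the change, a 1.7-fold higher number from compound 2 to compound 4 (0.24 log units; within the scatter) and so, at this amide-type nitrogen, 4-chlorophenyl and benzyl cannot be told apart. The earlier compounds shown here held no pair that differs in one place, so they could not show this. Nothing measured here offers an explanation for the result. From the compounds shown here alone, what remains open is how a plain phenyl would read at this nitrogen, which would separate the chlorine from the rest of the change. Also open, going by these compounds, is how an amine or a carboxylic acid on the ring, or a longer chain in place of benzyl, would read.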